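A few compounds are considered here, and "the series" means these few. Any claim that something is new, unique, unknown or untested is made for them only; others in the source may bear on it.

Measured in a functional assay (aorta) for antagonist activity, with Oryctolagus cuniculus as the target; on this read-out higher numbers stand for weaker inhibition and lower numbers for stronger inhibition:
compound 1 `CCCCc1ccc(CN)c(=O)n1Cc1ccc(-c2ccccc2-c2nn[nH]n2)cc1`: 20 nM
compound 2 `CCCCc1ccc(CNCc2ccccc2)c(=O)n1Cc1ccc(-c2ccccc2-c2nn[nH]n2)cc1`: 1 nM
compound 3 `CCCCc1ccc(CNC(=O)N(C)C)c(=O)n1Cc1ccc(-c2ccccc2-c2nn[nH]n2)cc1`: 2 nM

Compound 3 gives the second highest of the three numbers in this assay. The step of a 2.0-fold higher number from compound 2 to compound 3 (0.30 log units; within the scatter) lies within the scatter, whereas a 10-fold lower number from compound 1 to compound 3 (1.00 log units; beyond the scatter) lies beyond it. Compound 4 `CCCCc1ccc(CNS(=O)(=O)c2ccc(C)cc2)c(=O)n1Cc1ccc(-c2ccccc2-c2nn[nH]n2)cc1` is the next step: (4-methylphenyl)sulfonyl in place of dimethylcarbamoyl on an amine nitrogen. Both substitutions on that nitrogen so far lowered the number, a 20-fold lower number from compound 1 to compound 2 (1.30 log units; beyond the scatter) and a 10-fold lower number from compound 1 to compound 3 (1.00 log units; beyond the scatter), while exchanging one substituent for another gave a 2.0-fold higher number from compound 2 to compound 3 (0.30 log units; within the scatter). The change to compound 4 is again an exchange of one substituent for another, and it brings in a six-membered aromatic ring of carbon only, as the benzyl of compound 2 does. No step beyond the scatter is therefore expected in this assay. The estimate for compound 4 is 2 nM, range 0.7 nM to 6 nM, which means an expected no change at the digits printed from compound 3 to compound 4 (within the scatter).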

Compound 4, half-maximal inhibitory concentration: 9 nM
For compound 4 the middle estimate is 4.5-fold (0.65 log units) below the measured one; measured number above the stated range.
By their numbers in this assay, from the lowest: compounds 2 and 3 (each within the scatter of the next); then compound 4; then compound 1.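

The amine nitrogen does not accept every substituent alike: (4-methylphenyl)sulfonyl gives a 4.5-fold higher number from compound 3 to compound 4 (0.65 log units; beyond the scatter) and a 9.0-fold higher number from compound 2 to compound 4 (0.95 log units; beyond the scatter), so a six-membered aromatic ring of carbon only on this nitrogen does not by itself match compound 2. Substitution still keeps a lower number than the unsubstituted amine, with a 2.2-fold lower number from compound 1 to compound 4 (0.35 log units; beyond the scatter). No supporting data bear on the difference between these substituents.

As far as these compounds go, it remains open whether the sulfonyl link or the 4-methylphenyl group sets this result. Methylsulfonyl or benzoyl on the same nitrogen would separate the two.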